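The compounds below may be only part of what the source reports. "The series", "measured", "known", "first", "only" and "open" are said of these compounds alone.

Measured compounds:
compound 1 `c1ccc2sc(SCCCCn3ccnc3)nc2c1` — 800 nM
compound 2 `Clc1ccc2sc(SCCCCn3ccnc3)nc2c1` — 900 nM

Within the data shown here, in an assay on microsomes from brain (strain Sprague-Dawley) for inhibition of heme oxygenase 2 (Rattus norvegicus), read by spectrophotometry, with a stated time of 60 min (a lower number here means a stronger inhibitor, a higher number a weaker inhibitor), compound 2 and compound 1 sit within the scatter of each other; the only measured step, a 1.1-fold higher number from compound 1 to compound 2 (0.05 log units; within the scatter), concerns a chloro in place of hydrogen on an aromatic carbon and says nothing about the linker.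

Compound 3 `Clc1ccc2sc(SCCCCCn3ccnc3)nc2c1` differs from compound 2 by (1H-imidazol-1-yl)methyl in place of 1H-imidazol-1-yl on a saturated chain carbon, four bonds along the chain from a sulfur. Among the measured compounds shown here, no measured step bears on this lengthening of the chain, so the expectation rests on the absence of any large effect so far. The expected step is no change at the digits printed from compound 2 to compound 3 (within the scatter), with no change beyond the scatter assumed. Compound 3 is estimated at 900 nM, in the range 300 nM to 2700 nM.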

Compound 3, half-maximal inhibitory concentration: 900 nM
Compound 3: middle estimate and measured number agree at the digits printed; measured number inside the range.
By their numbers in this assay, from the lowest: compounds 1, 2 and 3 (each within the scatter of the next).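

Among these compounds, at the saturated chain carbon, four bonds along the chain from a sulfur, (1H-imidazol-1-yl)methyl in place of 1H-imidazol-1-yl gives no change at the digits printed from compound 2 to compound 3 (within the scatter) in this assay, the first reading on the chain. The earlier step concerned only a chloro on an aromatic carbon. No available evidence accounts for this result.

Still open, from the compounds shown here alone, is whether a longer chain, such as 2-(1H-imidazol-1-yl)ethyl at this place, stays within the scatter of compound 3. Also open, going by these compounds, is how an amine in place of 1H-imidazol-1-yl would read.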